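Replacing the 3,4-dimethoxyphenyl of compound 1

The compounds below may be only part of what the source reports. "The series", "measured", "known", "first", "only" and "open" are said of these compounds alone.

In a functional assay on SW480 cells (Homo sapiens) for antiproliferative activity, read by sulforhodamine B assay, with a stated time of 48 h (on this read-out lower numbers stand for stronger inhibition and higher numbers for weaker inhibition), compound 1 `COc1ccc(OC)c(/C=C/C(=O)c2ccccc2-c2ccc(OC)c(OC)c2)c1` gives 5200 nM. Compound 2 `COc1ccc(-c2ccccc2C(=O)/C=C/c2ccc(Br)cc2)cc1OC` gives 6500 nM. For the measured compounds named here, these are the only two measured values, and neither compound ranks ahead of the other. Compound 3 `COc1ccc(OC)c(/C=C/C(=O)c2ccccc2-c2ccc(F)cc2)c1` has 4-fluorophenyl in place of 3,4-dimethoxyphenyl on an aromatic carbon, ortho to a large group: 4-fluorophenyl in place of 3,4-dimethoxyphenyl on an aromatic carbon. Going by the values given here, the one measured step is a 1.3-fold higher number from compound 1 to compound 2 (0.10 log units; within the scatter). It concerns a different place, 4-bromophenyl in place of 2,5-dimethoxyphenyl, and compound 2 keeps 3,4-dimethoxyphenyl, so no measurement tests the present change directly. That step offers only weak guidance, and no step beyond the scatter is expected in this assay, with wide uncertainty in both directions. The estimated step is a 1.2-fold higher number from compound 1 to compound 3 (0.06 log units; within the scatter). Compound 3 is expected at 6000 nM, with an estimated range of 2000 nM to 15000 nM.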

Compound 3, half-maximal inhibitory concentration: 2400 nM
Beside the measured number, compound 3's estimate is 2.5-fold (0.40 log units) above it, within the range that was stated.
By their numbers in this assay, from the lowest: compound 3; then compounds 1 and 2 (each within the scatter of the next).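

In this assay, for the compounds shown here, this position on an aromatic carbon, ortho to a large group, gives the first step beyond the scatter: a 2.2-fold lower number from compound 1 to compound 3 (0.34 log units; beyond the scatter), a modest change with 4-fluorophenyl in place of 3,4-dimethoxyphenyl. In this single pair, 3,4-dimethoxyphenyl is not required for activity, and the group with 7 heavy atoms and 0 hydrogen-bond acceptors is tolerated in place of the one with 10 heavy atoms and 2 hydrogen-bond acceptors. No measurement at hand accounts for the step.

The fluorine enters as both methoxy groups leave, so the pair cannot assign the step to either event; plain phenyl, 4-methoxyphenyl or 4-aminophenyl at this position would separate them. Going by these compounds, whether 4-fluorophenyl here combines with 4-bromophenyl at the other position also remains open.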